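The source may hold more compounds than are shown below. What is called first, only, known or untested is meant among the compounds shown, and "the series" means these compounds.

Compound 1 `COc1ccc(/C=N\NC(=S)NC(C)(C)CCC[C@](C)(O)[C@@H]2CC=C(C)CC2)cc1` gives > 100000 nM in a functional assay on NCI-H460 cells (Homo sapiens) for cytotoxicity, read by sulforhodamine B assay (on this read-out lower numbers stand for stronger inhibition of growth and higher numbers for weaker inhibition of growth), which is a limit of the assay and not a number. Within the data shown here, compound 2 `CC1=CC[C@@H]([C@@](C)(O)CCCC(C)(C)NC(=S)N/N=C\c2cccc([N+](=O)[O-])c2)CC1` gives 68600 nM in this assay, the only actual number so far, so its standing can be judged only against (the limit of > 100000 nM in this assay, at which 1 of the 2 values shown sits). Compound 3 `CC1=CC[C@@H]([C@@](C)(O)CCCC(C)(C)NC(=S)N/N=C\c2ccc(Cl)cc2)CC1` differs from compound 2 by 4-chlorophenyl in place of 3-nitrophenyl on a carbon with a double bond to nitrogen. Among the measured compounds shown here, the one measured step that bears on this change is an at least 1.4-fold lower number from compound 1 to compound 2 (0.16 log units; that floor lies within the scatter), an exchange of groups at that same carbon. For the measured compounds named here, with only that small step as a guide, no shift beyond the scatter is expected in this assay, in either direction. The estimated move is a 1.1-fold lower number from compound 2 to compound 3 (0.06 log units; within the scatter). For compound 3 the expected value is 60000 nM, with an estimated range of 22000 nM to 120000 nM.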

Compound 3, concentration for total growth inhibition: > 100000 nM
Compound 3 gave a limit, no number; the forecaster's own chance of this, stated with the estimate: 30%; middle value at least 1.6-fold (0.22 log units) from the limit.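

In this assay, 4-chlorophenyl in place of 3-nitrophenyl on a carbon with a double bond to nitrogen gives an at least 1.4-fold higher number from compound 2 to compound 3 (0.16 log units; that floor lies within the scatter). Among these compounds, this is only a floor, so the true size of the change remains unknown, but 4-chlorophenyl now joins 4-methoxyphenyl in ending at a limit of the assay, and 3-nitrophenyl is the only one of the three groups with an actual number: the limit of > 100000 nM in this assay, at which 2 of the 3 values shown sit. The step between compound 1 and compound 3 cannot be read, as both are limits.

As far as these compounds go, it remains open whether compound 2 truly separates from compound 1 and compound 3, or whether its number merely falls close to the limit. Also open, from the compounds shown here alone, is how an amine or a carboxylic acid on the aromatic ring at this place would read out.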